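A Larger Ring Amine on the Side Chain of Compound 2

This account rests on a few compounds, and the source may have more. Where it says the series, first, only, none or still open, it means among the compounds named here.

Compound 1 `CC(C)NCCNc1ccnc2cc(Cl)ccc12` and compound 2 `CN(C)CCC(NCCNc1ccnc2cc(Cl)ccc12)c1ccccc1` share one core with a chain that carries an amine. In an assay on nucleic acid for binding affinity to Nucleic Acid, read by fluorescence, at pH 7.5 (on this read-out lower numbers stand for tighter binding and higher numbers for weaker binding), compound 1 gives 8000 nM, and compound 2 gives 8000 nM, level with compound 1 within the scatter. Compound 3 `Clc1ccc2c(NCCNC(CCN3CCCCC3)c3ccccc3)ccnc2c1` differs from compound 2 only by piperidin-1-yl in place of dimethylamino on a saturated chain carbon, three bonds along the chain from an amine nitrogen and an aromatic carbon. For the measured compounds named here, no measured pair isolates this change. In this assay the step is expected to be small, a 1.3-fold lower number from compound 2 to compound 3 (0.12 log units; within the scatter), if anything toward tighter binding. Compound 3 is expected to bind at about 6000 nM, within a range of 2000 nM to 20000 nM.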

Compound 3, dissociation constant: 4000 nM
Compound 3: middle estimate off by 1.5-fold (0.18 log units), on the high side; measured number inside the range.
By their numbers in this assay, from the lowest: compounds 3, 1 and 2 (each within the scatter of the next).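

Piperidin-1-yl in place of dimethylamino on this saturated chain carbon gives a 2.0-fold lower number from compound 2 to compound 3 (0.30 log units; within the scatter) in this assay and so leaves the read-out level within the scatter. This place on the chain therefore takes a six-membered ring amine as well as the open dimethylamino group. Nothing measured here speaks to why the two compounds read alike.

Going by these compounds, whether a smaller pyrrolidine ring, a morpholine ring or a carboxylic acid would also read level at this place stays open. So does the effect of a longer chain leading to the ring amine.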